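Swapping a Dimethoxyphenyl for a Chlorophenyl-Ethenyl Arm

A few compounds are considered here, and "the series" means these few. Any claim that something is new, unique, unknown or untested is made for them only; others in the source may bear on it.

Two compounds share one core and differ in a single group on an aromatic carbon. Compound 1 `COC(=O)/C=C/c1cccc(N(Cc2ccc(/C=C/c3scnc3C)cc2)C(=O)C(C)C)c1` carries a 2-(4-methyl-1,3-thiazol-5-yl)ethenyl group there, and in an assay on isolated protein with Bile acid receptor (Homo sapiens) as the target (a lower number here means that less compound is needed, a higher number that more compound is needed for the effect), compound 1 gives 228 nM. Going by the values given here, compound 2 `COC(=O)/C=C/c1cccc(N(Cc2ccc(-c3c(OC)cccc3OC)cc2)C(=O)C(C)C)c1` carries a 2,6-dimethoxyphenyl group instead; in this assay compound 2 gives 95 nM, the lowest of the two numbers, and the one measured step, a 2.4-fold lower number from compound 1 to compound 2 (0.38 log units; beyond the scatter), marks that gap. Compound 3 `COC(=O)/C=C/c1cccc(N(Cc2ccc(/C=C/c3cccc(Cl)c3)cc2)C(=O)C(C)C)c1` changes the same position again: 2-(3-chlorophenyl)ethenyl in place of 2,6-dimethoxyphenyl on an aromatic carbon. Among the compounds with values here, the entering group, like the group in compound 1, holds a double bond outside aromatic rings, so the only measured step is the guide, and its direction is expected to reverse in part, giving a modest rise. Compound 3 is therefore expected to give 200 nM in this assay, within 80 nM to 500 nM. That expectation corresponds to a 2.1-fold higher number from compound 2 to compound 3 (0.32 log units; beyond the scatter).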

Compound 3, half-maximal effective concentration: 164 nM
The estimate for compound 3 lay 1.2-fold (0.09 log units) above the measured number; low and high end bracket the measured number.
By their numbers in this assay, from the lowest: compounds 2, 3 and 1 (each within the scatter of the next, the first and the last beyond it).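

In this assay, putting 2-(3-chlorophenyl)ethenyl in place of 2,6-dimethoxyphenyl gives a 1.7-fold higher number from compound 2 to compound 3 (0.24 log units; within the scatter) and so, unlike the earlier step, this change at the position cannot be told apart from repeat-measurement noise. Exchanging the ring at the end of the ethenyl arm, 3-chlorophenyl for 4-methyl-1,3-thiazol-5-yl, gives a 1.4-fold lower number from compound 1 to compound 3 (0.14 log units; within the scatter) and shows that these two ethenyl-linked rings also read alike here, leaving only compound 1 and compound 2 clearly apart. No available evidence accounts for these numbers.

From the compounds shown here alone, it remains open whether the ethenyl link itself matters, which a 3-chlorophenyl group attached directly to the aromatic carbon could test. Also open, going by these compounds, is how an amine or a carboxylic acid on the end ring would read in this assay at this position.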